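Moving the isopropyl group on a glycoside aryl ether

A few compounds are considered here, and "the series" means these few. Any claim that something is new, unique, unknown or untested is made for them only; others in the source may bear on it.

Compound 3 `CO[C@@H]1O[C@H](COc2cccc(C(C)C)c2)[C@@H](O)[C@H](O)[C@H]1Oc1ccc(OC2CCCCC2)cc1` gives 41000 nM in a functional assay on A549 cells (Homo sapiens) for cytotoxicity, read by MTT assay, with a stated time of 48 h (a lower number here means that less compound is needed, a higher number that more compound is needed for the effect), the highest of the three numbers; compound 1 `CO[C@H]1O[C@H](COc2ccccc2C(C)C)[C@@H](O)[C@H](O)[C@H]1Oc1ccc(OC2CCCCC2)cc1` gives 33000 nM, within the scatter of compound 3, while compound 2 `CO[C@H]1O[C@H](COc2ccc(C3CCCCC3)cc2)[C@@H](O)[C@H](O)[C@H]1Oc1ccc(OC2CCCCC2)cc1` gives 12000 nM, the lowest. Going by the values given here, the only measured step at this oxygen, a 2.8-fold lower number from compound 1 to compound 2 (0.44 log units; beyond the scatter), concerns a different pair of groups. Compound 4 `CO[C@@H]1O[C@H](COc2ccccc2C(C)C)[C@@H](O)[C@H](O)[C@H]1Oc1ccc(OC2CCCCC2)cc1` differs from compound 3 by 2-isopropylphenyl in place of 3-isopropylphenyl on an oxygen on a saturated carbon. Among the compounds with values here, no measured step exchanges these two groups, so for compound 4 a step of a 1.2-fold lower number from compound 3 to compound 4 (0.07 log units; within the scatter) is expected, which lies within the scatter. Compound 4 is therefore estimated at 35000 nM, with a range from 15000 nM to 80000 nM in this assay.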

Compound 4, half-maximal effective concentration: 41000 nM
Beside the measured number, compound 4's estimate is 1.2-fold (0.07 log units) below it, within the range that was stated.
By their numbers in this assay, from the lowest: compound 2; then compounds 1, 3 and 4 (each within the scatter of the next).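

Exchanging 3-isopropylphenyl for 2-isopropylphenyl on this oxygen gives no change at the digits printed from compound 3 to compound 4 (within the scatter) in this assay. Changing the configuration at one saturated ring carbon gives a 1.2-fold higher number from compound 1 to compound 4 (0.09 log units; within the scatter), and this pair tests configuration alone: the fact that compounds 1 and 4 differ only in the configuration as drawn. Among these compounds, then, neither the position of the isopropyl group tested here nor this stereocentre separates the numbers.

The compounds shown leave open whether an amine or a carboxylic acid in place of the isopropyl group would shift the number in this assay.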